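The compounds below may be only part of what the source reports. "The series", "measured", "known", "first", "only" and "open" are said of these compounds alone.

In a functional assay on CHO cells for antagonist activity at prostaglandin E2 receptor EP1 subtype (Homo sapiens), read by FLIPR and calcium flux (on this read-out higher numbers stand for weaker inhibition and lower numbers for stronger inhibition), compound 1, `Cc1ccc(S(=O)(=O)N(Cc2nnc(Cc3ccc(C(F)(F)F)cc3)o2)c2cccc(Cl)c2C)cc1`, gives 158 nM. Within the data shown here, compound 2, `Cc1ccc(S(=O)(=O)N(Cc2nnc(Cc3c(Cl)cccc3Cl)o2)c2cccc(Cl)c2C)cc1`, differs from it only in the group on a saturated chain carbon bound to an aromatic carbon, and the step of a 3.2-fold higher number from compound 1 to compound 2 (0.50 log units; beyond the scatter) leaves compound 2 with 501 nM, the higher of the two numbers so far, with compound 1 as its only neighbour.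

Compound 3, `COc1ccc(NCc2nnc(CN(c3cccc(Cl)c3C)S(=O)(=O)c3ccc(C)cc3)o2)cc1`, is not yet measured in this assay. The change from compound 2 to compound 3 is (4-methoxyphenyl)amino in place of 2,6-dichlorophenyl on a saturated chain carbon bound to an aromatic carbon. Among the measured compounds shown here, only one measured step touches this position, a 3.2-fold higher number from compound 1 to compound 2 (0.50 log units; beyond the scatter), and it exchanged one carbon-only aromatic ring for another; the move to a ring carried on an amino linker, with its own donor and acceptors, has no measured counterpart here. On that single step the position tolerates a change with a modest shift, so compound 3 is expected to stay within reach of compound 2, with the step of a 1.4-fold lower number from compound 2 to compound 3 (0.16 log units; within the scatter) meant as a rough expectation and a wide range. The estimate for compound 3 in this assay is 350 nM, expected between 80 nM and 1600 nM.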

Compound 3, inhibition constant: 79.4 nM
For compound 3 the middle estimate is 4.4-fold (0.64 log units) above the measured one, and the stated range ends above it.
By their numbers in this assay, from the lowest: compounds 3 and 1 (each within the scatter of the next); then compound 2.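

In this assay, the place on a saturated chain carbon bound to an aromatic carbon accepts (4-methoxyphenyl)amino in place of 2,6-dichlorophenyl with a 6.3-fold lower number from compound 2 to compound 3 (0.80 log units; beyond the scatter) and a clear gain on this read-out. Among these compounds, the earlier pair had exchanged only one carbon-only aromatic ring for another, whereas this change carries the ring on an amino linker and brings a hydrogen-bond donor and acceptors that 2,6-dichlorophenyl lacks, so the position is not confined to groups of the earlier kind. Set against 4-(trifluoromethyl)phenyl, the same group gives a 2.0-fold lower number from compound 1 to compound 3 (0.30 log units; within the scatter) and the two cannot be told apart, which leaves compound 2 as the one that stands off from both, and nothing shown here accounts for these steps.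

The compounds shown leave open whether the step from compound 2 follows the amino linker, the methoxy group or the loss of the two chlorines, as all of these change together. From the compounds shown here alone, a plain phenylamino group and a methoxyphenyl ring on a carbon linker would separate these parts, and the reach of the position toward a saturated amine such as piperidine also remains unknown.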